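This account rests on a few compounds, and the source may have more. Where it says the series, first, only, none or still open, it means among the compounds named here.

Measured so far in a functional assay on HCC1806 cells (Homo sapiens) for inhibition, read by sulforhodamine B assay, tested at 10 uM; a higher number here means more inhibition at the concentration tested (going by the name of the read-out), a lower number less inhibition:
compound 1 `CN1CCN(c2ccc(C3=NN(S(=O)(=O)c4ccc(Br)cc4)C(c4ccc(N(C)C)cc4)C3)cc2)CC1` gives 87.1%
compound 2 `Cc1ccc(S(=O)(=O)N2N=C(c3ccc(-n4cncn4)cc3)CC2c2ccc(N(C)C)cc2)cc1` gives 27.7%

Compound 2 stands lowest of the two numbers in this assay; the nearest, compound 1, lies higher by a gap beyond the usual scatter. The two differ in more than one place, so the gap is taken as it stands and is not assigned to any single change.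

Compound 3 `CN(C)c1ccc(C2CC(c3ccc(-n4cncn4)cc3)=NN2S(=O)(=O)c2ccc(Br)cc2)cc1` is not yet measured. It differs from compound 2 by bromo in place of methyl on an aromatic carbon, the (4-methylphenyl)sulfonyl group becoming (4-bromophenyl)sulfonyl. Among the compounds with values here, no step of exactly this kind between measured compounds is at hand, so the expectation rests on compound 2 itself and the wider spread of the two numbers.

In this assay a modest upward step is expected for compound 3, a number 12.3 percentage points higher from compound 2 to compound 3 (beyond the scatter), a step that may not clear the scatter. Compound 3 is estimated at 40%, with a range from 15% to 70%.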

Compound 3, a percentage reported as inhibition, at one concentration (the size of the read-out at that concentration, not a potency): 26.3%
Compound 3: middle estimate off by 13.7 percentage points, on the high side, within the range that was stated.
By their numbers in this assay, from the lowest: compounds 3 and 2 (each within the scatter of the next); then compound 1.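

With the 1H-1,2,4-triazol-1-yl group held in place, bromo in place of methyl on the sulfonyl-bound aromatic ring gives a number 1.4 percentage points lower from compound 2 to compound 3 (within the scatter) in this assay, so 4-methylphenyl and 4-bromophenyl are not separated in this pair. With the 4-bromophenylsulfonyl group held in place, 1H-1,2,4-triazol-1-yl in place of 4-methylpiperazin-1-yl gives a number 60.8 percentage points lower from compound 1 to compound 3 (beyond the scatter), which places a large single-change step at this second position, with compound 1 on the higher side. Nothing available explains the size of either step.

As far as these compounds go, whether bromo and methyl would also stay within the scatter with 4-methylpiperazin-1-yl in place remains open, as this comparison rests on a single pair. Also open, from the compounds shown here alone, is how a morpholin-4-yl group, a primary amine or a carboxylic acid would read on the aromatic carbon that carries the 4-methylpiperazin-1-yl group in compound 1.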